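Swapping the amide group on compound 1

A few compounds are considered here, and "the series" means these few. Any claim that something is new, unique, unknown or untested is made for them only; others in the source may bear on it.

Compound 1 `Cc1cnc(NC(=O)c2cc(Oc3cnc(C(=O)N(C)C)cn3)c3cc(C)oc3c2)cn1`: < 8.5 mL/min/kg (a limit, not a number)
Compound 2 `Cc1cnc(NC(=O)c2cc(Oc3ccc(S(C)(=O)=O)cc3)c3cc(C)oc3c2)cn1`: 13 mL/min/kg
Compound 3 `Cc1cnc(NC(=O)c2cc(Oc3ccc(C#N)cc3)c3cc(C)oc3c2)cn1`: 29 mL/min/kg

These values come from an ADME assay (liver) for metabolic stability, with Liver microsome (Homo sapiens) as the target, using microsomes; on this read-out lower numbers stand for slow clearance and higher numbers for fast clearance. On these data alone, compound 1 has only a limit, so its exact place on the scale is unknown. Compound 4 `Cc1cnc(NC(=O)c2cc(Oc3cnc(C(=O)N4CCCC4)cn3)c3cc(C)oc3c2)cn1` carries pyrrolidin-1-yl in place of dimethylamino on a carbonyl carbon. Among the measured compounds shown here, no measured step makes this change. The only one, a 2.2-fold higher number from compound 2 to compound 3 (0.35 log units; beyond the scatter), swaps a different group, so it offers only a rough guide to the size of a single swap in this assay. The expected step of an at least 1.2-fold higher number from compound 1 to compound 4 (0.11 log units; that floor lies within the scatter) is therefore modest and upward. For compound 4 the estimated value is 11 mL/min/kg, with an expected range of 5 mL/min/kg to 24 mL/min/kg.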

Compound 4, clearance: < 8.1 mL/min/kg
Compound 4 ended at the assay's limit (the forecaster's own chance of this, stated with the estimate: 40%); middle value at least 1.3-fold (0.13 log units) away from the limit.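

In this assay compound 4 gives < 8.1 mL/min/kg, a limit and not a number. Compound 1 also has only a limit, so the step between the two cannot be read. The compounds shown leave open how far apart their true clearances lie.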